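The compounds below may be only part of what the source reports. "The series", "measured", "known", "first", "only" and "open" are said of these compounds alone.

Three compounds have been measured in a functional assay on HT-29 cells (Homo sapiens) for cytotoxicity, read by MTT assay, with a stated time of 24 h, tested at 0.64 ug/mL; on this read-out lower numbers stand for a weaker effect and higher numbers for a stronger effect at the one concentration tested:

compound 1 `Cn1c(-c2ccc(NC(=O)CCl)cc2)nc(-c2ccccc2)c1-c1ccccc1` — 7.2%
compound 2 `Cn1ccnc1SCC(=O)Nc1ccc(-c2nc(-c3ccccc3)c(-c3ccccc3)n2C)cc1` — 13.6%
compound 3 `CCN1CCN(CC(=O)Nc2ccc(-c3nc(-c4ccccc4)c(-c4ccccc4)n3C)cc2)CC1` — 7.4%

All three share one core and differ only in the group on the saturated chain carbon bound to the carbonyl carbon. Compound 3 sits with its number between those of the other two, but the spread is small: the step of a number 0.2 percentage points higher from compound 1 to compound 3 (within the scatter) and the step of a number 6.2 percentage points lower from compound 2 to compound 3 (within the scatter) are both within the scatter, as is a number 6.4 percentage points higher from compound 1 to compound 2 (within the scatter). Among the compounds with values here, on these numbers no compound can be called stronger or weaker than another.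

Compound 4 `Cn1c(-c2ccc(NC(=O)CN3CCN(Cc4ccccc4)CC3)cc2)nc(-c2ccccc2)c1-c1ccccc1` is not yet measured. It differs from compound 3 in one place: phenyl in place of methyl on a saturated chain carbon bound to an amine nitrogen in a ring. Within the data shown here, none of the measured steps touches the group on the amine nitrogen in the ring; each of them exchanges the whole group on the saturated chain carbon bound to the carbonyl carbon, and even those larger exchanges gave nothing beyond the scatter. Among the measured compounds shown here, there is therefore no measured step that points to a change here, and the expectation for compound 4 in this assay is a step of a number 0.6 percentage points higher from compound 3 to compound 4 (within the scatter), that is, none beyond the scatter. Compound 4 is thus expected to give about 8%, estimated between 2% and 18%.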

Compound 4, a percentage reported as activity, at one concentration (the size of the read-out at that concentration, not a potency): 15.5%
The estimate for compound 4 lay 7.5 percentage points below the measured number; the range from low to high includes it.
By their numbers in this assay, from the lowest: compounds 1, 3, 2 and 4 (each within the scatter of the next).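

In this assay, within the data shown here, the exchange of methyl for phenyl on a saturated chain carbon bound to an amine nitrogen in a ring, which reads as ethyl to benzyl when cut one bond further out, gave a number 8.1 percentage points higher from compound 3 to compound 4 (within the scatter) and thus gave the first reading for this place. The earlier steps shown here each exchanged the whole group on the saturated chain carbon bound to the carbonyl carbon, whereas this one shows that a six-membered aromatic ring of carbon only can enter on the piperazine side of the molecule without a step beyond the scatter. Nothing in the information available explains the size of this step or ties it to any property of the phenyl group.

The compounds shown leave open whether a longer chain, or a benzyl carrying a chloro or methoxy group, at this place would give a step beyond the scatter. They also leave open how the four compounds compare in potency, as a reading at one concentration gives the size of the effect there and no potency.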